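The source may report more compounds than this note shows. Statements on the series, on what has been measured and on what is new or still open speak of the compounds shown alone.

In a functional assay on CNE-2 cells (Homo sapiens) for antiproliferative activity, read by sulforhodamine B assay, with a stated time of 48 h (on this read-out higher numbers stand for weaker inhibition and lower numbers for stronger inhibition), compound 3 (`COc1ccc(/C=C/C(=O)c2ccccc2-c2cccc(F)c2)cc1`) gives 73 nM. That lies within the scatter of compound 1 (`COc1ccc(/C=C/C(=O)c2ccccc2-c2ccc(F)cc2)cc1`), which gives 53 nM, and far from compound 2 (`O=C(/C=C/c1cccs1)c1ccccc1-c1ccc(F)cc1`), which gives 5900 nM. Compound 4 (`COc1ccc(/C=C/C(=O)c2ccccc2-c2cccnc2)cc1`) has pyridin-3-yl in place of 3-fluorophenyl on an aromatic carbon. The closest evidence is a change at this same place, a 1.4-fold higher number from compound 1 to compound 3 (0.14 log units; within the scatter), which is small. For the measured compounds named here, the one large step, a 110-fold higher number from compound 1 to compound 2 (2.05 log units; beyond the scatter), lies elsewhere in the molecule and bears only loosely. Going by the values given here, no measured compound carries pyridin-3-yl, so the forecast is uncertain. A moderate change is expected in this assay: a 2.5-fold higher number from compound 3 to compound 4 (0.39 log units; beyond the scatter). The estimated value for compound 4 is 180 nM, with a range from 50 nM to 700 nM.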

Compound 4, half-maximal inhibitory concentration: 64 nM
Compound 4: middle estimate off by 2.8-fold (0.45 log units), on the high side, within the range that was stated.
By their numbers in this assay, from the lowest: compounds 1, 4 and 3 (each within the scatter of the next); then compound 2.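

In this assay the pyridin-3-yl ring matches both fluorophenyl rings, with a 1.1-fold lower number from compound 3 to compound 4 (0.06 log units; within the scatter) and a 1.2-fold higher number from compound 1 to compound 4 (0.08 log units; within the scatter) both within the scatter. Until now, this place had shown only a shift of fluorine around the ring; now a ring containing nitrogen, with a hydrogen-bond acceptor, also keeps the number in the same range. Nothing available explains this match. Still open, as far as these compounds go, is whether this place would accept a phenyl ring carrying a carboxylic acid or an amine, and whether a small group such as methyl could replace the ring altogether.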